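Alkoxy chain variation on the shared core: phenyl to pyridin-3-yl

The source may hold more compounds than are shown below. What is called first, only, known or untested is meant among the compounds shown, and "the series" means these compounds.

Measured compounds:
- compound 1 `CCc1sc(CCc2cc(OC)cc(NCc3cc(Cl)cc(NC(=O)OC(C)C)c3)n2)nc1C`: 234 nM
- compound 2 `CC/C=C\CCOc1cc(CCc2nc(C)c(CC)s2)nc(NCc2cc(Cl)cc(NC(=O)OC(C)C)c2)c1`: 4.7 nM
- compound 3 `CCc1sc(CCc2cc(OCCCc3ccccc3)cc(NCc3cc(Cl)cc(NC(=O)OC(C)C)c3)n2)nc1C`: 20 nM

In an assay on cells for binding affinity to Neuropeptide Y receptor type 1 (Homo sapiens) (on this read-out lower numbers stand for stronger inhibition and higher numbers for weaker inhibition), compound 3 stands second highest of the three; the nearest number is that of compound 2, the furthest that of compound 1. The measured steps all concern the chain on the aromatic oxygen: a 50-fold lower number from compound 1 to compound 2 (1.70 log units; beyond the scatter) and a 12-fold lower number from compound 1 to compound 3 (1.07 log units; beyond the scatter), both large, and a 4.3-fold higher number from compound 2 to compound 3 (0.63 log units; beyond the scatter), modest.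

Compound 4 `CCc1sc(CCc2cc(OCCCc3cccnc3)cc(NCc3cc(Cl)cc(NC(=O)OC(C)C)c3)n2)nc1C` carries the change (pyridin-3-yl in place of phenyl on a saturated chain carbon, three bonds along the chain from an oxygen on an aromatic ring). For the measured compounds named here, no measured step touches this kind of exchange; the three measured steps describe lengthening or reshaping the chain, not swapping one ring for another of the same size at its end. They therefore give no direction for the new step, only the observation that the chain end matters to this assay. The expectation for compound 4 is a step of a 1.5-fold higher number from compound 3 to compound 4 (0.18 log units; within the scatter), not beyond the scatter, and a value of 30 nM with a range from 10 nM to 100 nM is estimated.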

Compound 4, half-maximal inhibitory concentration: 6.5 nM
Compound 4: the middle estimate sits 4.6-fold (0.66 log units) above what was measured; measured number below the stated range.
By their numbers in this assay, from the lowest: compounds 2 and 4 (each within the scatter of the next); then compound 3; then compound 1.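

Pyridin-3-yl in place of phenyl, three bonds along the chain from the aromatic oxygen, is not a silent exchange in this assay (the step is a 3.1-fold lower number from compound 3 to compound 4 (0.49 log units; beyond the scatter)), so a ring nitrogen at the chain end changes the read-out even though the heavy-atom count stays the same. The aromatic chain end now stands level with the unsaturated chain, within the scatter (a 1.4-fold higher number from compound 2 to compound 4 (0.14 log units; within the scatter)), and the full 3-(pyridin-3-yl)propyl group retains a large step over the hydrogen-bearing reference (a 36-fold lower number from compound 1 to compound 4 (1.56 log units; beyond the scatter)). Nothing available accounts for this difference.

Going by these compounds, whether the step depends on where the nitrogen sits remains open, and pyridin-2-yl and pyridin-4-yl at the same chain end would test this. Also open, on these data alone, is how a pyrimidin-5-yl ring, a dimethylamino group or a longer chain would read at this place.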